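This account rests on a few compounds, and the source may have more. Where it says the series, first, only, none or still open, it means among the compounds named here.

In a functional assay on HepG2 cells (Homo sapiens) for inhibition, read by MTT assay, with a stated time of 48 h (a lower number here means a stronger inhibitor, a higher number a weaker inhibitor), compound 1, with the structure `COc1ccc(N(C)c2nc(C)nc3ccccc23)cc1OCCN`, gives 343 nM. Among the three compounds measured so far, this is the highest number. Compound 2, `C[Se]c1ccc(N(C)c2nc(C3CC3)nc3ccccc23)cc1`, gives 32 nM in this assay, and compound 3, `C[Se]c1ccc(N(C)c2nc(C)nc3ccccc23)cc1C`, gives 6 nM; the number for compound 1 lies beyond the usual scatter above both of them, so compound 1 is the weakest inhibitor of the three.

The account now turns to compound 4, `COc1ccc(N(C)c2nc(C)nc3ccccc23)cc1C(=O)OCCCC[Se]C#N`, which has not yet been measured in this assay. It differs from compound 1 in one place: a group of 10 heavy atoms (6 carbon, 1 nitrogen, 2 oxygen, 1 selenium; no ring) in place of a group of 4 heavy atoms (2 carbon, 1 nitrogen, 1 oxygen; no ring), on an aromatic carbon. The new group is built from six carbon, one nitrogen, two oxygen and one selenium atom and carries one double bond and one triple bond, in place of the 2-aminoethoxy group of compound 1.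

Among the compounds with values here, no measured pair in this set shows this change, so its size can only be expected, not read off. The two compounds that contain selenium, compound 2 with 32 nM and compound 3 with 6 nM, give lower numbers than compound 1, but their selenium sits in a different place and on a different partner group. A step of a 2.3-fold lower number from compound 1 to compound 4 (0.36 log units; beyond the scatter) toward a lower number is therefore expected, with wide uncertainty. For compound 4 the estimate is 150 nM, within a range from 30 nM to 800 nM.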

Compound 4, half-maximal inhibitory concentration: 975 nM
The estimate for compound 4 lay 6.5-fold (0.81 log units) below the measured number; the whole stated range lies below it.
By their numbers in this assay, from the lowest: compound 3; then compound 2; then compound 1; then compound 4.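

In this assay, within the data shown here, the exchange of the 2-aminoethoxy group for the larger selenium-bearing group gives a 2.8-fold higher number from compound 1 to compound 4 (0.45 log units; beyond the scatter), the first step in this set that can be read between two compounds differing in one place. It shows that this position, on an aromatic carbon ortho to a methoxy group, accepts a group of 10 heavy atoms with no hydrogen-bond donor at the cost of only a modest rise in the number, and that in this one pair, bringing in selenium does not give a lower number. Nothing measured here bears on why the number rises.

This single step changes the whole group at once, so the compounds shown leave open whether the rise belongs to the carbonyl, the chain, the selenium or the nitrile, or to the loss of the amine. They also leave open how a shorter chain, a sulfur atom in place of the selenium, or a carboxylic acid on the same aromatic carbon would read in this assay.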